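This account rests on a few compounds, and the source may have more. Where it says the series, first, only, none or still open, it means among the compounds named here.

Three compounds have been measured in an assay on Sf9 cells for inhibition of mitogen-activated protein kinase kinase kinase 14 variant S549D (Homo sapiens), with a stated time of 30 min, in the presence of a further agent that is not named here; on this read-out higher numbers stand for weaker inhibition and lower numbers for stronger inhibition:

Compound 1, `CCc1ccc2ncn(-c3ccnc(N)n3)c2c1`, gives 79400 nM.
Compound 2, `C=CC(=O)NCC#Cc1ccc2ncn(-c3ccnc(N)n3)c2c1`, gives 6310 nM.
Compound 3, `CC(=O)NCCCc1ccc2ncn(-c3ccnc(N)n3)c2c1`, gives only a limit of the assay, > 100000 nM.

Of the two real numbers, compound 2 holds the lower one. The nearest step is a 13-fold lower number from compound 1 to compound 2 (1.10 log units; beyond the scatter), a large gain that came with 3-((vinylcarbonyl)amino)prop-1-yn-1-yl in place of ethyl on an aromatic carbon. In the other direction stands an at least 15-fold higher number from compound 2 to compound 3 (1.19 log units; beyond the scatter), where 3-acetamidopropyl took the place of that group. Compound 3 sits at the limit of > 100000 nM in this assay, at which 1 of the 3 values shown sits.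

Compound 4, `C=Cc1ccnc(C#Cc2ccc3ncn(-c4ccnc(N)n4)c3c2)c1`, keeps the triple bond of compound 2 but changes what hangs on it: a group of 8 heavy atoms (7 carbon, 1 nitrogen; one six-membered aromatic ring with 1 hetero atom) in place of a group of 6 heavy atoms (4 carbon, 1 nitrogen, 1 oxygen; no ring), on a triple-bonded carbon. Both large measured steps turn on the 3-((vinylcarbonyl)amino)prop-1-yn-1-yl group, and compound 4 gives up its ((vinylcarbonyl)amino)methyl part while keeping the triple bond and one double bond outside aromatic rings. The number in this assay is therefore expected to move toward weaker inhibition, though with wide uncertainty. The expected step is a 3.2-fold higher number from compound 2 to compound 4 (0.50 log units; beyond the scatter). Compound 4 is thus estimated at 20000 nM, with a range from 4000 nM to 100000 nM.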

Compound 4, half-maximal inhibitory concentration: 1580 nM
Estimate against measurement, compound 4: 13-fold (1.10 log units) above, outside the stated range (below it).
By their numbers in this assay, from the lowest: compound 4; then compound 2; then compound 1. At a limit, above all of these: compound 3.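

With the triple bond kept, replacing the ((vinylcarbonyl)amino)methyl part with a group of 8 heavy atoms that holds one six-membered aromatic ring with 1 hetero atom gives a 4.0-fold lower number from compound 2 to compound 4 (0.60 log units; beyond the scatter) in this assay. The earlier compounds shown here showed the gain only for the open chain with its amide, whereas this change shows that the amide is not needed for a number this low, since the entering group has 0 hydrogen-bond donors and no carbonyl. A ring-bearing group of more heavy atoms is also accepted on this triple-bonded carbon, and the size of the step is modest.

The measurements shown give no explanation for why the ring-bearing group does better. As far as these compounds go, it stays open whether the double bond outside the aromatic ring matters, and whether a plain phenyl ring or an amine in its place would do as well.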